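Long-chain series: effect of a chain double bond

A few compounds are considered here, and "the series" means these few. Any claim that something is new, unique, unknown or untested is made for them only; others in the source may bear on it.

Measured so far:
- compound 1 `CCCCCCCC/C=C\CCCCCCCCOc1cc(O)c(C(C)=O)c(O)c1`; in a functional assay on HeLa cells (Homo sapiens) for cytotoxicity, read by XTT assay, with a stated time of 72 h (on this read-out lower numbers stand for stronger inhibition and higher numbers for weaker inhibition), compound 1 gives 31000 nM
- compound 2 `CCCCCCCCCCCCCCCCCCc1c(O)cc(O)c(C(C)=O)c1O`; in this assay compound 2 gives 26000 nM
- compound 3 `CCCCCCCCCCCCCCCCCCOc1cc(O)c(C(C)=O)c(O)c1`; in this assay compound 3 gives > 100000 nM, which is a limit of the assay and not a number

Compound 3 and compound 1 differ in one place: dec-1-en-1-yl in place of decyl on a saturated chain carbon, eight bonds along the chain from an oxygen on an aromatic ring. In this assay this gives an at least 3.2-fold lower number from compound 3 to compound 1 (0.50 log units; beyond the scatter). The full size of this step cannot be fixed because compound 3 sits at the limit of > 100000 nM in this assay, at which 1 of the 3 values shown sits. The values of compound 2 and compound 1 lie within the scatter of each other, so no order is drawn between them. Compound 2 and compound 3 have the same atoms joined differently; the difference between the two cores is not broken down here.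

Compound 4 `CCCCCCCC/C=C\CCCCCCCCc1c(O)cc(O)c(C(C)=O)c1O` is not yet measured in this assay. It differs from compound 2 by dec-1-en-1-yl in place of decyl on a saturated chain carbon, eight bonds along the chain from an aromatic carbon. This is the same kind of change as that from compound 3 to compound 1, though the place is not the same: in compound 2 the chain is counted from an aromatic carbon, in compound 3 from an oxygen on an aromatic ring. From compound 2 a step of a 2.9-fold lower number from compound 2 to compound 4 (0.46 log units; beyond the scatter) is expected, resting on the step of an at least 3.2-fold lower number from compound 3 to compound 1 (0.50 log units; beyond the scatter) seen for the same kind of change. Compound 4 is estimated at 9000 nM in this assay, expected to lie between 3000 nM and 30000 nM.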

Compound 4, half-maximal inhibitory concentration: > 100000 nM
Compound 4: only a limit was reported; the forecaster's own chance of this, stated with the estimate: 5%; middle value at least 11-fold (1.04 log units) from the limit.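

In this assay, replacing decyl with dec-1-en-1-yl on the core of compound 2 gives an at least 3.8-fold higher number from compound 2 to compound 4 (0.58 log units; beyond the scatter), whereas the same change on the core of compound 3 gives an at least 3.2-fold lower number from compound 3 to compound 1 (0.50 log units; beyond the scatter). Within these four compounds the change therefore does not carry from one core to the other, and the step on one core gives no guide to the step on the other: the same change on two cores in this assay, an at least 3.2-fold lower number (0.50 log units; beyond the scatter) from compound 3 to compound 1 and an at least 3.8-fold higher number (0.58 log units; beyond the scatter) from compound 2 to compound 4, at least 12-fold (1.09 log units) apart, beyond the scatter of two such steps The direction of each step can be read, but neither size is fixed, as compound 3 and compound 4 each stand at a limit of the assay and not at a number, and one pair per core shows no general rule and no cause for the reversal: the limit of > 100000 nM in this assay, at which 2 of the 4 values shown sit.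

On these data alone, it remains open whether the opposite directions persist with other chains on these two cores, such as a longer chain carrying the same double bond or a chain ending in a carboxylic acid or an amine. As far as these compounds go, it also remains open whether a double bond elsewhere along the chain would give the same result on each core.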